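The compounds below may be only part of what the source reports. "The series", "measured", "known", "first", "only" and "open" are said of these compounds alone.

Series so far in a physicochemical assay for metabolic stability, read by HPLC and mass spectrometry, in phosphate buffer, at 37 degrees C, at pH 7.4 (on this read-out lower numbers stand for a shorter-lived compound and higher numbers for a longer-lived compound), each entry a limit and not a number:
- compound 1 `CC(C)(O/N=C(\C(=O)N[C@@H]1C(=O)N(S(=O)(=O)O)[C@@H]1CN1CCC1=O)c1csc(N)n1)C(=O)O` gives > 1000 h (limit)
- compound 2 `CC(C)(O/N=C(\C(=O)N[C@@H]1C(=O)N(S(=O)(=O)O)[C@@H]1CN1CCCC1=O)c1csc(N)n1)C(=O)O` gives > 1000 h (limit)
- compound 3 `CC(C)(O/N=C(\C(=O)N[C@@H]1C(=O)N(S(=O)(=O)O)[C@@H]1Cn1cc(CO)nn1)c1csc(N)n1)C(=O)O` gives > 37 h (limit)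

Compound 3 stands at > 37 h, which is a limit, so its true half-life is not known.

The next change leads to compound 4 `CC(C)(O/N=C(\C(=O)N[C@@H]1C(=O)N(S(=O)(=O)O)[C@@H]1Cn1ncnc1CNC(=N)N)c1csc(N)n1)C(=O)O` and is a group of 10 heavy atoms (4 carbon, 6 nitrogen; one five-membered aromatic ring with 3 hetero atoms) in place of a group of 7 heavy atoms (3 carbon, 3 nitrogen, 1 oxygen; one five-membered aromatic ring with 3 hetero atoms), on a saturated chain carbon bound to a saturated ring carbon. The 4-(hydroxymethyl)-1H-1,2,3-triazol-1-yl group leaves, and both groups hold one five-membered aromatic ring with 3 hetero atoms.

The measured steps that bear on this are a step that the two limits leave unreadable from compound 1 to compound 3 and a step that the two limits leave unreadable from compound 2 to compound 3, and neither gives a size. The same holds for a step that the two limits leave unreadable from compound 1 to compound 2. Within the data shown here, no measured compound yet carries the entering group.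

With no readable size to go on, no direction can be argued. What is expected in this assay is a step that the limit leaves unreadable from compound 3 to compound 4, nothing beyond the scatter.

The estimate for compound 4 is 60 h, with an expected range of 15 h to 500 h, and it may well be reported only as a limit.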

Compound 4, half-life: > 37 h
Compound 4: no number, only a limit (the forecaster's own chance of this, stated with the estimate: 55%); the middle value is on the limit's open side.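

All four entries are limits, and the steps from compound 1, compound 2 and compound 3 to compound 4 cannot be read. The compounds shown leave open the actual half-life of each compound and whether the exchanged groups differ at all on this read-out.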